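The source may report more compounds than this note shows. Statements on the series, on what has been measured and on what is new or still open speak of the compounds shown alone.

Two members of the series have been run in a functional assay on the whole organism (strain CF-1) with Mus musculus as the target; on this read-out higher numbers stand for an effect only at larger amounts of compound and lower numbers for an effect already at smaller amounts. Compound 1 `Cc1nnc(CN2CCCC2)n1-c1ccc(Cl)cc1C(=O)c1ccccc1` gives 4 mg/kg in this assay. Compound 2 `CNCc1nnc(C)n1-c1ccc(Cl)cc1C(=O)c1ccccc1`, bearing methylamino in place of pyrrolidin-1-yl on a saturated chain carbon bound to an aromatic carbon, gives 2.5 mg/kg in this assay; the step of a 1.6-fold lower number from compound 1 to compound 2 (0.20 log units; within the scatter) stays within the scatter, so the two values cannot be told apart. Compound 3 `CCNCc1nnc(C)n1-c1ccc(Cl)cc1C(=O)c1ccccc1` carries methyl in place of hydrogen on a saturated chain carbon bound to an amine nitrogen, the same difference cut one bond further out reading methylamino to ethylamino. Going by the values given here, no measured step touches the substituent on the amine nitrogen: the one step measured so far, a 1.6-fold lower number from compound 1 to compound 2 (0.20 log units; within the scatter), replaces the whole amine and was itself within the scatter. With nothing pointing to a shift in either direction, the expected step of no change at the digits printed from compound 2 to compound 3 (within the scatter) is none beyond the scatter. Compound 3 is therefore estimated at 2.5 mg/kg in this assay, with a range from 1.2 mg/kg to 5.5 mg/kg.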

Compound 3, dose for half-maximal effect: 2.5 mg/kg
Estimate against measurement, compound 3: no gap at the digits printed; low and high end bracket the measured number.
By their numbers in this assay, from the lowest: compounds 2, 3 and 1 (each within the scatter of the next).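

Methyl in place of hydrogen on a saturated chain carbon bound to an amine nitrogen is the first measured change to the substituent on this amine, and in this assay it reads no change at the digits printed from compound 2 to compound 3 (within the scatter). Ethylamino in place of pyrrolidin-1-yl reads a 1.6-fold lower number from compound 1 to compound 3 (0.20 log units; within the scatter), so pyrrolidin-1-yl, methylamino and ethylamino on this chain carbon cannot be told apart in this assay. No independent measurement is available to interpret this flat reading.

From the compounds shown here alone, it remains open whether a longer chain such as butyl on the amine nitrogen, or a bare amino group carrying no carbon substituent, would give a number beyond the scatter of these three. Also open, going by these compounds, is how an amide or a carboxylic acid would read in place of the amine.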